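A few compounds are considered here, and "the series" means these few. Any claim that something is new, unique, unknown or untested is made for them only; others in the source may bear on it.

Measured so far:
- Compound 1 `Cc1nc(C)c([C@H](OC(C)(C)C)C(=O)O)c(N2CCC(C)(C)CC2)c1-c1ccc(OCCc2cc(F)c(F)cc2F)cc1`: in an ADME assay on microsomes from liver (Rattus norvegicus) for metabolic stability, read by LC-MS, tested at 0.5 uM (a lower number here means that the compound disappears faster, a higher number that the compound lasts longer), compound 1 reaches > 2 h, which is a limit of the assay rather than a number.
- Compound 2 `Cc1nc(C)c([C@H](OC(C)(C)C)C(=O)O)c(N2CCC(C)(C)CC2)c1-c1ccc(OCCc2ccccn2)cc1`: in this assay compound 2 gives 1.02 h.

Among the compounds with values here, compound 2 holds the only numeric value shown; the other entry sits at the limit of > 2 h in this assay, at which 1 of the 2 values shown sits. Within the data shown here, the one measured step, an at least 1.9-fold lower number from compound 1 to compound 2 (0.29 log units; that floor lies within the scatter), has a floor within the scatter. Compound 3 `Cc1ncsc1CCOc1ccc(-c2c(C)nc(C)c([C@H](OC(C)(C)C)C(=O)O)c2N2CCC(C)(C)CC2)cc1` carries 4-methyl-1,3-thiazol-5-yl in place of pyridin-2-yl on a saturated chain carbon, two bonds along the chain from an oxygen on an aromatic ring. Among the measured compounds shown here, no measured step covers this swap, so no shift beyond the scatter is assumed: a 1.0-fold lower number from compound 2 to compound 3 (0.01 log units; within the scatter) is the expected step. Compound 3 is therefore estimated at 1 h, between 0.5 h and 2 h.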

Compound 3, half-life: > 2 h
Compound 3 ended at the assay's limit; the forecaster's own chance of this, stated with the estimate: 15%; middle value at least 2.0-fold (0.30 log units) away from the limit.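

At this position, on a saturated chain carbon, two bonds along the chain from an oxygen on an aromatic ring, 4-methyl-1,3-thiazol-5-yl in place of pyridin-2-yl gives in this assay an at least 1.9-fold higher number from compound 2 to compound 3 (0.29 log units; that floor lies within the scatter). Compound 1 and compound 3, with different aromatic rings at this place, both stand at a limit and not at a number: the limit of > 2 h in this assay, at which 2 of the 3 values shown sit. The step between these two cannot be read, so their groups cannot be ranked.

From the compounds shown here alone, how a morpholine or a longer chain at this place would read in this assay remains open. So does the true size of the step to compound 3, whose printed floor lies within the scatter.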